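Single stereocentre inversion on the ring of compound 3

A few compounds are considered here, and "the series" means these few. Any claim that something is new, unique, unknown or untested is made for them only; others in the source may bear on it.

The series is read in an assay on HEK293 cells for agonist activity at probable G-protein coupled receptor 34 (Mus musculus), with a stated time of 1 h; a higher number here means a larger maximal response, a lower number a smaller maximal response. Compound 1 `CCCCCCCC/C=C\CCCCCCCC(=O)OC[C@@H](COC)OP(=O)(O)OC[C@H](N)C(=O)O` gives 12.9%. Compound 2 `CCCCCCCCCCCOc1ccccc1CCC(=O)O[C@H]1COCC[C@H]1OP(=O)(O)OC[C@H](N)C(=O)O` gives 3.7%, and compound 3 `CCCCCCCCCCCOc1ccccc1CCC(=O)O[C@@H]1COCC[C@@H]1OP(=O)(O)OC[C@H](N)C(=O)O` gives 6.4%. On these three numbers compound 3 sits between the other two, nearer to compound 2 and further from compound 1, and both gaps lie inside the usual scatter, so the three maximal responses cannot be told apart.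

Among the compounds with values here, the only measured step that touches the same part of the molecule is a number 2.7 percentage points higher from compound 2 to compound 3 (within the scatter); the one note recorded on that pair is the fact that one of compounds 2 and 3 is drawn with a defined configuration and the other without, at the place where they differ. Compound 4 `CCCCCCCCCCCOc1ccccc1CCC(=O)O[C@@H]1COCC[C@H]1OP(=O)(O)OC[C@H](N)C(=O)O` differs from compound 3 as follows: the two compounds have the same atoms and bonds; at least one stereo element is drawn with a configuration in one of them and without one in the other: 1 of 4 stereo elements differ; a stereocentre at a saturated ring carbon is drawn S in compound 3 and R in compound 4. Since turning both ring stereocentres at once moved the maximal response by nothing beyond the scatter, turning one of them alone is expected to move it by nothing beyond the scatter either, and the step of a number 0.4 percentage points lower from compound 3 to compound 4 (within the scatter) is the expected outcome. Compound 4 is accordingly estimated at 6%, with a range from 0% to 14%.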

Compound 4, largest response reached (Emax), in percent of the reference or control that the assay uses: 10%
Beside the measured number, compound 4's estimate is 4 percentage points below it, and the stated range covers the measured number.
By their numbers in this assay, from the lowest: compounds 2, 3, 4 and 1 (each within the scatter of the next).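

In this assay, a single inversion at a ring stereocentre gives a number 3.6 percentage points higher from compound 3 to compound 4 (within the scatter), and a single inversion starting from the other isomer gives a number 6.3 percentage points higher from compound 2 to compound 4 (within the scatter). The ring stereocentres, turned singly as well as together, therefore produce no maximal response that can be told apart, and compounds 2, 3 and 4 show no preferred configuration at this position. The only note recorded on the single inversion describes how the pair is drawn and offers no cause: the fact that one of compounds 3 and 4 is drawn with a defined configuration and the other without, at the place where they differ

Going by these compounds, whether the remaining combination of the two ring stereocentres would separate from compounds 2, 3 and 4 stays open. Also open, on these data alone, is whether a change away from these stereocentres, such as an amide in place of the ester or a shorter alkyl chain, would move the response beyond the scatter.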